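Longer ester chains on the shared core: working notes

This account rests on a few compounds, and the source may have more. Where it says the series, first, only, none or still open, it means among the compounds named here.

Compound 1 `CCCCCOC(=O)CCC(=O)N1CCN(CCCOc2cc3c(Nc4ccc(F)c(Cl)c4)ncnc3cc2OC)CC1`: 87.1%
Compound 2 `CCCCCCCOC(=O)CCC(=O)N1CCN(CCCOc2cc3c(Nc4ccc(F)c(Cl)c4)ncnc3cc2OC)CC1`: 89.1%
Compound 3 `CCCCCCCCCOC(=O)CCC(=O)N1CCN(CCCOc2cc3c(Nc4ccc(F)c(Cl)c4)ncnc3cc2OC)CC1`: 90%

In a functional assay on A549 cells (Homo sapiens) for cytotoxicity, read by MTT assay, with a stated time of 24 h, tested at 10 uM (a higher number here means a weaker effect of the compound at the concentration tested, a lower number a stronger effect), compound 3 gives the highest of the three numbers, yet it sits within the scatter of both compound 2 and compound 1. Compound 4 `CCCCCCCCCCCCCCCOC(=O)CCC(=O)N1CCN(CCCOc2cc3c(Nc4ccc(F)c(Cl)c4)ncnc3cc2OC)CC1` differs from compound 3 by hexyl in place of hydrogen on a saturated chain carbon, nine bonds along the chain from an oxygen next to a carbonyl group. Going by the values given here, the steps that bear on this are a number 2 percentage points higher from compound 1 to compound 2 (within the scatter), a number 2.9 percentage points higher from compound 1 to compound 3 (within the scatter) and a number 0.9 percentage points higher from compound 2 to compound 3 (within the scatter), each a lengthening of the same chain and each within the scatter. No movement beyond the scatter is therefore expected in this assay for compound 4, though the step of a number 1 percentage points higher from compound 3 to compound 4 (within the scatter) is estimated to lie in the same direction. Compound 4 is expected to give 91%, with a range from 84% to 97%.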

Compound 4, a percentage reported as activity, at one concentration (the size of the read-out at that concentration, not a potency): 92%
Estimate against measurement, compound 4: 1 percentage points below, and the stated range covers the measured number.
By their numbers in this assay, from the lowest: compounds 1, 2, 3 and 4 (each within the scatter of the next).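

Hexyl at this position, nine bonds along the chain from an oxygen next to a carbonyl group, gives a number 2 percentage points higher from compound 3 to compound 4 (within the scatter) in this assay. The wider spans also hold, with a number 2.9 percentage points higher from compound 2 to compound 4 (within the scatter) and a number 4.9 percentage points higher from compound 1 to compound 4 (within the scatter), so even the addition of decyl to the chain of compound 1 stays within the scatter. Nothing at hand explains this flat read-out.

Still open, going by these compounds, is whether an amine or a carboxylic acid at the end of the ester chain would give a step beyond the scatter.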